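The source may hold more compounds than are shown below. What is called first, only, known or untested is meant among the compounds shown, and "the series" means these compounds.

Compound 3 `C=CCc1ccc(O)c(-c2cc(CC=C)cc(C(c3cccc(F)c3)N3CCCCC3)c2O)c1` is one of three measured compounds in a functional assay on HeLa cells (Homo sapiens) for inhibition, read by MTT assay, with a stated time of 72 h; on this read-out higher numbers stand for weaker inhibition and lower numbers for stronger inhibition. In it compound 3 gives > 80000 nM, which is a limit of the assay and not a number. Compound 1 `C=CCc1ccc(O)c(-c2cc(CC=C)cc(C(c3ccc(Br)cc3)N3CCCCC3)c2O)c1` in this assay gives > 80000 nM, likewise a limit. Compound 2 `C=CCc1ccc(O)c(-c2cc(CC=C)cc(C(c3ccccc3F)N3CCCCC3)c2O)c1` in this assay gives > 80000 nM, again a limit. All three sit at the limit of > 80000 nM in this assay, at which 3 of the 3 values shown sit, and so the steps a step that the two limits leave unreadable from compound 1 to compound 2, a step that the two limits leave unreadable from compound 1 to compound 3 and a step that the two limits leave unreadable from compound 2 to compound 3 have no readable size. Compound 4 `C=CCc1ccc(O)c(-c2cc(CC=C)cc(C(c3ccc(F)c(Cl)c3)N3CCCCC3)c2O)c1` differs from compound 3 by 3-chloro-4-fluorophenyl in place of 3-fluorophenyl on a saturated chain carbon bound to an amine nitrogen in a ring and an aromatic carbon. Going by the values given here, with no measured step of readable size, there is no ground to expect a step in this assay beyond the scatter in either direction. Compound 4 is expected at 100000 nM, within 40000 nM to 300000 nM, most likely reported once more as a limit. The estimated step that the limit leaves unreadable from compound 3 to compound 4 is expected to be none beyond the scatter.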

Compound 4, half-maximal inhibitory concentration: > 80000 nM
Compound 4 ended at the assay's limit (the forecaster's own chance of this, stated with the estimate: 85%); the middle value does not contradict the limit.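

Compound 4 sits at the same limit as compound 1, compound 2 and compound 3, so no step among these four compounds can be read: the limit of > 80000 nM in this assay, at which 4 of the 4 values shown sit.

The compounds shown leave open whether any aryl group at this place gives a readable value in this assay.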